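Swapping a Lactam for an Open Hydroxy Chain

The compounds below may be only part of what the source reports. "The series", "measured", "known", "first", "only" and "open" are said of these compounds alone.

Compound 1 `CC1(C)Cc2c(sc(NC(=O)c3ccccc3O)c2C(N)=O)CO1`: 13 nM
Compound 2 `CC1(C)Cc2c(sc(NC(=O)C3CCNC3=O)c2C(N)=O)C(C)(C)O1`: 101 nM

Of the compounds shown here, two have been tested in an assay on cells for positive allosteric modulation of Cystic fibrosis transmembrane conductance regulator variant F508del (Homo sapiens), with stated times of 10 min and 7 s, in the presence of a further agent that is not named here; on this read-out lower numbers stand for an effect already at smaller amounts and higher numbers for an effect only at larger amounts of compound. Compound 2 gives 101 nM, the higher of the two numbers. Compound 1 gives 13 nM, and the gap between the two lies beyond the usual scatter. Going by the values given here, the two structures differ in more than one place, so no single step connects them, and the gap cannot be tied to one change.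

Compound 3 `CC(C)(C)CC(O)C(=O)Nc1sc2c(c1C(N)=O)CC(C)(C)OC2(C)C` has not yet been measured. It differs from compound 2 in one place: a group of 7 heavy atoms (6 carbon, 1 oxygen; no ring) in place of a group of 6 heavy atoms (4 carbon, 1 nitrogen, 1 oxygen; one five-membered non-aromatic ring with 1 hetero atom), on a carbonyl carbon. The entering group, like the leaving one, carries a hydrogen-bond donor and a hydrogen-bond acceptor, but it is an open chain rather than a five-membered ring.

Among the compounds with values here, with no measured step of this kind available, the expectation rests on the two values alone. Compound 3 is estimated at about 60 nM, with a range from 15 nM to 250 nM. The expected step of a 1.7-fold lower number from compound 2 to compound 3 (0.23 log units; within the scatter) is modest, toward a lower number, and might not exceed the scatter.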

Compound 3, half-maximal effective concentration: 0.54 nM
The estimate for compound 3 lay 110-fold (2.05 log units) above the measured number; measured number outside the range, below it.
By their numbers in this assay, from the lowest: compound 3; then compound 1; then compound 2.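

Going by these compounds alone, at this position, on a carbonyl carbon whose other neighbour is an amide-type nitrogen, the choice of group has a very strong effect: in this assay, replacing the 2-oxopyrrolidin-3-yl ring with the open chain gives a 190-fold lower number from compound 2 to compound 3 (2.27 log units; beyond the scatter) and this is the first measured change that can be tied to a single place in the structure. The two groups have the same counts of hydrogen-bond donors and acceptors, yet their numbers lie far apart, so those counts alone do not predict the result at this position, and the open chain shows that a ring is not required here for a very low number. The data shown offer no measurement that explains why this swap has such a large effect.

Going by these compounds, it remains open which part of the open chain matters most, the hydroxy group or the carbon chain that carries it, and whether an amine in place of that hydroxy group, or a shorter or longer chain, would keep the number as low. On these data alone, it is also open whether the same open chain would give a similar gain on the core of compound 1, whose ring system differs from that of compound 3.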